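Pyrazole removal at the aryl position of the shared core

This account rests on a few compounds, and the source may have more. Where it says the series, first, only, none or still open, it means among the compounds named here.

Measured compounds:
compound 1 `c1cc(-c2ccn[nH]2)c2c(c1)C(c1ncc[nH]1)CC2` gives 336 nM in a functional assay on CHO cells for agonist activity at Alpha-1D adrenergic receptor (Homo sapiens), read by FLIPR and calcium flux; on this read-out higher numbers stand for an effect only at larger amounts of compound and lower numbers for an effect already at smaller amounts
compound 2 `Cn1ccc(-c2cccc3c2CCC3c2ncc[nH]2)n1` gives > 10000 nM in this assay

Compound 2 stands at the upper end of the numbers shown. Its value of > 10000 nM is a limit of this assay and not a number, as noted for (the limit of > 10000 nM in this assay, at which 1 of the 2 values shown sits). Among the compounds with values here, compound 1, which differs from it by the pyrazole substitution pattern, gives 336 nM; the step of an at least 29-fold higher number from compound 1 to compound 2 (1.47 log units; beyond the scatter) is the only measured step, and it is large.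

Compound 3 `c1ccc2c(c1)CCC2c1ncc[nH]1` removes the heteroaryl group altogether: hydrogen in place of 1-methyl-1H-pyrazol-3-yl on an aromatic carbon. Within the data shown here, no measured step covers the loss of the whole group, so the change from compound 2 to compound 3 is read only against the one step known. That step shows the shared core tolerates no methylated pyrazole at this position, which gives no sign that the bare core would fare better.

Compound 3 is therefore expected to remain at or near the limit, with the step that the limit leaves unreadable from compound 2 to compound 3 estimated as within the scatter. The estimate for compound 3 is 15000 nM, in the range 3000 nM to 60000 nM.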

Compound 3, half-maximal effective concentration: > 10000 nM
Compound 3 ended at the assay's limit; the forecaster's own chance of this, stated with the estimate: 60%; the middle value does not contradict the limit.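

In this assay the shared core without any heteroaryl group no longer gives a measurable effect: compound 3 gives > 10000 nM, which is a limit of the assay and not a number. Hydrogen in place of 1H-pyrazol-5-yl on an aromatic carbon brings an at least 29-fold higher number from compound 1 to compound 3 (1.47 log units; beyond the scatter), so the core alone does not carry the activity seen for compound 1, and among the three compounds only the one bearing 1H-pyrazol-5-yl at this place has a measured number. The step from the methylated pyrazole to hydrogen cannot be read, and compound 2 and compound 3 cannot be ranked against each other: the limit of > 10000 nM in this assay, at which 2 of the 3 values shown sit.

Open, going by these compounds, is whether a group other than a pyrazole at this place, such as an amine, a carboxylic acid or a phenyl ring, would give a measurable value in this assay. Also open, on these data alone, is whether the loss seen with 1-methyl-1H-pyrazol-3-yl is specific to the methyl group, which an ethyl group or a longer chain on the same ring nitrogen could test.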